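Compound 4: Piperazine Amide Derived From Compound 2

A few compounds are considered here, and "the series" means these few. Any claim that something is new, unique, unknown or untested is made for them only; others in the source may bear on it.

In an assay on HEK293 cells for displacement of a labelled ligand from NPC1-like intracellular cholesterol transporter 1 (Homo sapiens) (a higher number here means a weaker inhibitor, a lower number a stronger inhibitor), compound 2 `CC(C)(C)c1ccc(C(=O)N2CCC3(CC2)C(=O)N(CC(=O)NCN)CN3c2ccccc2)cc1` gives 26500 nM, the highest of the three numbers recorded. Compound 1 `CC(C)(C)OC(=O)NCC1CCCN(C(=O)CN2CN(c3ccccc3)C3(CCN(C(=O)c4ccc(C5CCCCC5)cc4)CC3)C2=O)C1` gives 3800 nM and compound 3 `NC(=O)C1CCCN(C(=O)CN2CN(c3ccccc3)C3(CCN(C(=O)c4ccc(C5CCCCC5)cc4)CC3)C2=O)C1` gives 3100 nM; the step of a 1.2-fold lower number from compound 1 to compound 3 (0.09 log units; within the scatter) is small, and both compounds sit beyond the scatter below compound 2. Compound 4 `CC(C)(C)c1ccc(C(=O)N2CCC3(CC2)C(=O)N(CC(=O)N2CCNCC2)CN3c2ccccc2)cc1` arises from compound 2 by the change (piperazin-1-yl in place of (aminomethyl)amino on a carbonyl carbon). Among the compounds with values here, no measured step touches this position directly; compounds 1 and 3 carry a saturated ring on that carbonyl carbon but also differ from compound 2 elsewhere, so they offer only a loose hint that such a ring is tolerated. A modest downward step, a 2.2-fold lower number from compound 2 to compound 4 (0.34 log units; beyond the scatter), is therefore expected, with wide uncertainty. The estimate for compound 4 in this assay is 12000 nM, expected between 3000 nM and 45000 nM.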

Compound 4, half-maximal inhibitory concentration: 22000 nM
Estimate against measurement, compound 4: 1.8-fold (0.26 log units) below; the range from low to high includes it.
By their numbers in this assay, from the lowest: compounds 3 and 1 (each within the scatter of the next); then compounds 4 and 2 (each within the scatter of the next).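

In this assay putting piperazin-1-yl in place of (aminomethyl)amino on this carbonyl carbon gives a 1.2-fold lower number from compound 2 to compound 4 (0.08 log units; within the scatter) and so leaves the number within the scatter, even with a six-membered ring entering. Within the data shown here, this is the first direct reading at this position, which compounds 1 and 3 could not give, as they also differ from compound 2 elsewhere. Nothing available accounts for this result.

From the compounds shown here alone, whether a morpholine ring, a carboxylic acid or a longer chain on this carbonyl carbon would give a step beyond the scatter remains open.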